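The source may hold more compounds than are shown below. What is called first, only, known or untested is meant among the compounds shown, and "the series" means these compounds.

Of the compounds shown here, three built on a shared core have been measured in an in vitro ADME assay on microsomes from liver (Homo sapiens) for metabolic stability; a higher number here means faster removal of the compound, a lower number slower removal: compound 1 `CC(C)(C)CCC1(C(=O)c2cc3ccccc3s2)CCNC1` gives 22 mL.min-1.g-1, compound 2 `Cc1cccc2nc(C(=O)C3(CCC(C)(C)C)CCNC3)ccc12` gives 25 mL.min-1.g-1, and compound 3 `CC(C)(C)CCC1(C(=O)c2cc(Cl)c(Cl)s2)CCNC1` gives 17 mL.min-1.g-1. These numbers all lie within the usual scatter of one another, so compound 2 stands level with the other two. Compound 4 `CC(C)(C)CCC1(C(=O)c2ccc3ccccc3n2)CCNC1` differs from compound 2 by a single change, hydrogen in place of methyl on an aromatic carbon. Among the measured compounds shown here, no measured pair shows this change directly. For the measured compounds named here, the only guide is how closely the three measured values agree, so no shift beyond the scatter is expected in this assay. The expected step, a 1.2-fold lower number from compound 2 to compound 4 (0.08 log units; within the scatter), is estimated to stay within the scatter. Compound 4 is expected at about 21 mL.min-1.g-1, with an estimated range of 12 mL.min-1.g-1 to 36 mL.min-1.g-1.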

Compound 4, intrinsic clearance in microsomes: 35 mL.min-1.g-1
The estimate for compound 4 lay 1.7-fold (0.22 log units) below the measured number; measured number inside the range.
By their numbers in this assay, from the lowest: compounds 3, 1, 2 and 4 (each within the scatter of the next, the first and the last beyond it).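

In this assay, among the compounds shown here, hydrogen in place of methyl on this aromatic carbon gives a 1.4-fold higher number from compound 2 to compound 4 (0.15 log units; within the scatter), the first direct reading of this change. At this position, the methyl and the hydrogen therefore cannot be told apart in this measurement. No measurement is at hand that would explain the result. Going by these compounds, whether another group on this carbon, such as a methoxy group, a fluorine atom or an amine, would also stay within the scatter remains open. So does whether the same change would read alike elsewhere on this six-membered ring.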